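The compounds below may be only part of what the source reports. "The series", "measured", "known", "first", "only" and "open" are said of these compounds alone.

Measured so far:
compound 1, `NCCNC(=O)c1c(O)c2ccccc2n(-c2ccccc2)c1=O`: 1.4% in a functional assay, with a stated time of 20 min, tested at 0.5 mM; a lower number here means a weaker effect, a higher number a stronger effect of the compound at the concentration tested
compound 2, `Cn1c(=O)c(C(=O)NCCCCCCN)c(O)c2ccccc21`: 13.7% in this assay

Compound 2 stands highest of the two numbers. Its nearest neighbour on the scale is compound 1, whose activity lies lower by a gap that is beyond the usual scatter. Among the measured compounds shown here, the two compounds differ in more than one place, so their values show only that compound 2 gives the stronger read-out.

Compound 3, `NCCCCCCNC(=O)c1c(O)c2ccccc2n(-c2ccccc2)c1=O`, has not yet been measured in this assay. It differs from compound 2 in one place: phenyl in place of methyl on an aromatic nitrogen. For the measured compounds named here, no comparison between measured compounds isolates this change, so its size and direction are open. Compound 1, which also carries the phenyl, gives 1.4%, which leaves room for a decrease. The account expects a modest downward step from compound 2 to compound 3, a number 5.7 percentage points lower from compound 2 to compound 3 (within the scatter), possibly within the scatter. The activity of compound 3 in this assay is estimated at 8%, within a range from 0% to 24%.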

Compound 3, a percentage reported as activity, at one concentration (the size of the read-out at that concentration, not a potency): 19.3%
For compound 3 the middle estimate is 11.3 percentage points below the measured one, within the range that was stated.
By their numbers in this assay, from the lowest: compound 1; then compounds 2 and 3 (each within the scatter of the next).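

In this assay, phenyl in place of methyl on the aromatic nitrogen gives a number 5.6 percentage points higher from compound 2 to compound 3 (within the scatter), so at this position six carbons and an aromatic ring in place of a single carbon leave the read-out indistinguishable from that of the methyl compound. Compound 1 and compound 3 both carry the phenyl, and 4-aminobutyl in place of amino on the saturated chain carbon gives a number 17.9 percentage points higher from compound 1 to compound 3 (beyond the scatter), which shows that the phenyl alone does not set the low read-out of compound 1. Nothing given here explains either step.

On these data alone, compound 1 and compound 2 differ in two places, so what the chain does with methyl on the nitrogen remains open. Also open, as far as these compounds go, is how a benzyl group on that nitrogen, or a carboxylic acid in place of the terminal amine, would read out.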